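Chain Lengthening on the Amino Alcohol Arm of Compound 1

This account rests on a few compounds, and the source may have more. Where it says the series, first, only, none or still open, it means among the compounds named here.

Measured compounds:
compound 1 `COc1cc(/C=C/C(=O)/C=C(/C=C/c2ccc(O)c(OC)c2)NCCO)ccc1O`, 96.6%
compound 2 `COc1cc(/C=C/C2=CC(=O)CC(c3ccc(O)c(OC)c3)N2CCCO)ccc1O`, 91%
compound 3 `O=C(/C=C(/C=C/c1ccc(O)cc1)NCCCO)/C=C/c1ccc(O)cc1`, 91.7%

In a functional assay on Caco-2 cells (Homo sapiens) for activation, read by fluorescence, tested at 10 uM (on this read-out higher numbers stand for a weaker effect at the one concentration tested and lower numbers for a stronger effect), compound 1 gives 96.6%, the largest of the three numbers, yet the gaps to compound 3 and to compound 2 both fall within the scatter, so the three compounds cannot be told apart on this read-out. Compound 4 `COc1cc(/C=C/C(=O)/C=C(/C=C/c2ccc(O)c(OC)c2)NCCCO)ccc1O` has not been measured; it differs from compound 1 by hydroxymethyl in place of hydroxy on a saturated chain carbon, two bonds along the chain from an amine nitrogen. Within the data shown here, no measured pair differs by this change alone, so the data give no step to lean on. Compound 3, which carries the 3-hydroxypropyl chain, gives 91.7% in this assay, close to compound 1. The step of a number 3.6 percentage points lower from compound 1 to compound 4 (within the scatter) is therefore expected to be none beyond the scatter. Compound 4 is estimated at 93%, between 84% and 101%.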

Compound 4, a percentage reported as activity, at one concentration (the size of the read-out at that concentration, not a potency): 91%
Compound 4: the middle estimate sits 2 percentage points above what was measured; measured number inside the range.
By their numbers in this assay, from the lowest: compounds 2, 4, 3 and 1 (each within the scatter of the next).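

In this assay, (3-hydroxypropyl)amino in place of (2-hydroxyethyl)amino gives a number 5.6 percentage points lower from compound 1 to compound 4 (within the scatter), the first step read at this position on an otherwise unchanged core. Hydroxymethyl in place of hydroxy on a saturated chain carbon, two bonds along the chain from an amine nitrogen, therefore leaves the two compounds indistinguishable on this read-out. Nothing available bears on what lies behind this result. On these data alone, whether a longer chain such as 4-hydroxybutyl, or a carboxylic acid at this position, would give a step beyond the scatter remains open.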